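Replacing bromomethyl with methoxycarbonyl in a cytotoxicity series

The compounds below may be only part of what the source reports. "The series", "measured", "known", "first", "only" and "open" are said of these compounds alone.

Compound 1 `O=C(O)CCn1c2ccc([N+](=O)[O-])cc2c(=O)n1Cc1ccccc1` gives > 256000 nM as a limit
Compound 2 `O=[N+]([O-])c1ccc2nn(Cc3ccccc3)c(OCCCBr)c2c1` gives 59000 nM as a measured number

Both compounds were tested in an ADME assay on L929 cells (Mus musculus) for cytotoxicity, read by resazurin assay, with a stated time of 48 h; a higher number here means that more compound is tolerated, a lower number that less compound is tolerated. The reading for compound 1 is a limit of the assay and not a number. Among the compounds with values here, that leaves compound 2, at 59000 nM, with the only true number so far, and a single number cannot yet place it within a wider series.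

Compound 3 `COC(=O)CCOc1c2cc([N+](=O)[O-])ccc2nn1Cc1ccccc1` keeps the core of compound 2 and alters only the end of its chain: methoxycarbonyl in place of bromomethyl on a saturated chain carbon, two bonds along the chain from an oxygen on an aromatic ring. Methoxycarbonyl stands in place of bromomethyl on a saturated chain carbon, two bonds along the chain from an oxygen on an aromatic ring. Read one bond further out, 3-bromopropoxy becomes 2-(methoxycarbonyl)ethoxy.

Within the data shown here, no two measured compounds differ in one place only, which makes any forecast a cautious one. A moderate rise in the tolerated concentration is expected, taking compound 2 at 59000 nM as the starting point. The expected change is a step of a 1.9-fold higher number from compound 2 to compound 3 (0.27 log units; within the scatter) in this assay. Compound 3 is estimated at 110000 nM, with an expected range of 45000 nM to 256000 nM.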

Compound 3, concentration lethal to 50% of the cells: > 256000 nM
Compound 3: only a limit was reported; the forecaster's own chance of this, stated with the estimate: 25%; at least 2.3-fold (0.36 log units) between middle value and limit.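

In this assay, methoxycarbonyl in place of bromomethyl, on a saturated chain carbon, two bonds along the chain from an oxygen on an aromatic ring, gives an at least 4.3-fold higher number from compound 2 to compound 3 (0.63 log units; beyond the scatter). Within the data shown here, this is the first comparison here between two compounds that differ in one place, and it shows that the end of this chain matters: with the shared core held constant, the cells tolerate less of the compound carrying 3-bromopropoxy than of the one carrying 2-(methoxycarbonyl)ethoxy. The step gives only a minimum size because compound 3 is reported as a limit and not as a number: the limit of > 256000 nM in this assay, at which 2 of the 3 values shown sit.

One pair cannot show whether the difference comes from losing bromomethyl or from gaining methoxycarbonyl, since both happen in the same change. A chain ending in a chloromethyl group or an amine at this same position would help separate the two, although any new compound that also reaches the limit would leave its step to compound 3 unreadable.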